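The compounds below may be only part of what the source reports. "The series", "measured", "known", "first", "only" and "open" are said of these compounds alone.

Measured compounds in a functional assay on DU-145 cells (Homo sapiens) for antiproliferative activity, read by sulforhodamine B assay, with a stated time of 72 h; a higher number here means a weaker inhibitor of growth, a lower number a stronger inhibitor of growth:
compound 1, `Cc1cc(=O)oc2cc(Sc3cccc(Cl)n3)ccc12`, 1150 nM
compound 2, `Cc1cc(=O)oc2cc(SCc3ccccn3)ccc12`, > 35200 nM
compound 3, `CCc1oc2c(C)c(OC)ccc2c(=O)c1Br`, > 33600 nM

Of the three, only compound 1 gives a number in this assay, 1150 nM. For compound 2 this assay reports only a limit, > 35200 nM, which is the limit of > 35200 nM in this assay, at which 1 of the 3 values shown sits. For compound 3 this assay likewise reports only a limit, > 33600 nM, which is the limit of > 33600 nM in this assay, at which 1 of the 3 values shown sits. Compound 3 therefore stands at the limit of this assay, with no number behind it, and compound 2 sits at a limit as well; between these two nothing can be ordered. Among the measured compounds shown here, compound 1 and compound 3 share no common parent, so no step between measured compounds can be read from these three.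

Compound 4, `CCc1oc2c(C)c(OC(C)C)ccc2c(=O)c1Br`, is the next compound in the series and is not yet measured in this assay. It differs from compound 3 in one place: isopropyl in place of methyl on an oxygen on an aromatic ring. For the measured compounds named here, no measured pair shows what this change does here, and no other change has been measured either.

Given that compound 3 sits at a limit, the expectation for compound 4 is a step that the limit leaves unreadable from compound 3 to compound 4, with no direction that stands beyond the scatter. Compound 4 is therefore expected to give about 40000 nM, in the range from 10000 nM to 150000 nM, and most likely this assay will again report only a limit.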

Compound 4, concentration for 50% growth inhibition: > 30700 nM
Compound 4: no number, only a limit; the forecaster's own chance of this, stated with the estimate: 75%; the middle value is on the limit's open side.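

In this assay compound 4 gives only a limit, > 30700 nM. Compound 3 also gives only a limit, > 33600 nM. No step can be read between compound 3 and compound 4. The compounds shown leave open whether going from methoxy to isopropoxy changes growth inhibition in this series, and in which direction.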